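Methyl to trifluoromethyl at two different places on the core

This account rests on a few compounds, and the source may have more. Where it says the series, first, only, none or still open, it means among the compounds named here.

Compound 1 `Cc1nn(-c2cncc(C(C)(C)O)c2)c2ccccc12` in an ADME assay on cells for inhibition of cytochrome P450 11B1, mitochondrial (Homo sapiens), read by HTRF, with stated times of 1 h and 3 h (on this read-out lower numbers stand for stronger inhibition and higher numbers for weaker inhibition), gives 779 nM. For compound 2 `CC(C)(O)c1cncc(-n2nc(C(F)(F)F)c3ccccc32)c1` this assay reports only a limit, > 8300 nM. The change between them is trifluoromethyl in place of methyl on an aromatic carbon, and the step is an at least 10-fold higher number from compound 1 to compound 2 (1.02 log units; beyond the scatter), its size resting on (the limit of > 8300 nM in this assay, at which 1 of the 3 values shown sits).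

Compound 3 `Cc1ccc2c(cnn2-c2cncc(C(C)(C)O)c2)c1` in this assay gives 916 nM, a value within the scatter of that of compound 1; how the two cores differ is not broken down here.

Compound 4 `CC(C)(O)c1cncc(-n2ncc3cc(C(F)(F)F)ccc32)c1` is not yet measured. It differs from compound 3 by trifluoromethyl in place of methyl on an aromatic carbon. This is the same kind of change as that from compound 1 to compound 2, but the place is not the same: there the group sits on a five-membered aromatic ring with 2 nitrogen, next to the ring nitrogen, here on a six-membered aromatic ring of carbon only, meta and para to a fused ring. Among the measured compounds shown here, with only the step of an at least 10-fold higher number from compound 1 to compound 2 (1.02 log units; beyond the scatter) as precedent, and at a different place, a weaker step is expected, a 2.7-fold higher number from compound 3 to compound 4 (0.44 log units; beyond the scatter). Compound 4 is estimated at 2500 nM, between 900 nM and 8300 nM.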

Compound 4, half-maximal inhibitory concentration: 1200 nM
Estimate against measurement, compound 4: 2.1-fold (0.32 log units) above; the range from low to high includes it.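

Trifluoromethyl in place of methyl on the six-membered aromatic ring of carbon only gives a 1.3-fold higher number from compound 3 to compound 4 (0.12 log units; within the scatter). Set beside the earlier step, the same change does not carry from one core to the other at one size in this assay: the same change on two cores in this assay, an at least 10-fold higher number (1.02 log units; beyond the scatter) from compound 1 to compound 2 and a 1.3-fold higher number (0.12 log units; within the scatter) from compound 3 to compound 4, at least 8.1-fold (0.91 log units) apart, beyond the scatter of two such steps. This does not show whether the place of the group or the rest of the core sets that gap, since the two pairs differ in both, and the earlier step rests on a value that is a limit and not a number: the limit of > 8300 nM in this assay, at which 1 of the 4 values shown sits.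

Among the compounds shown here, with only two pairs, no rule for the series follows, and it stays open how the change behaves at either place on a single shared core. Also open, on these data alone, is whether other small groups on the six-membered ring, such as chlorine, a nitrile or a methoxy group, would stay as close to compound 3 as trifluoromethyl does in compound 4.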